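Replacing hexyloxy with octyl on a shared core

The compounds below may be only part of what the source reports. "The series", "measured", "known", "first", "only" and "open" are said of these compounds alone.

- compound 1 `CCCCCc1ccc(-c2c(C)[nH]c(=O)n2C2CCCCC2)cc1` gives 10600 nM
- compound 2 `CCCCCCOc1ccc(-c2c(C)[nH]c(=O)n2C2CCCCC2)cc1` gives 8500 nM

Within the data shown here, in a functional assay on brain (Rattus norvegicus, strain Wistar) for inhibition (a higher number here means a weaker inhibitor, a lower number a stronger inhibitor), only two numbers exist so far, and compound 2 (8500 nM) lies within the scatter of compound 1 (10600 nM). The two cannot be told apart on these data.

The next compound, compound 3 `CCCCCCCCc1ccc(-c2c(C)[nH]c(=O)n2C2CCCCC2)cc1`, carries octyl in place of hexyloxy on an aromatic carbon. Among the measured compounds shown here, one measured step bears on this change (a 1.2-fold lower number from compound 1 to compound 2 (0.10 log units; within the scatter)), with hexyloxy in place of pentyl on an aromatic carbon. For the measured compounds named here, that step stayed within the scatter, but no measured compound yet carries octyl, so the evidence is thin. No step beyond the scatter is therefore expected in this assay, and no direction can be favoured. The expected step is small (a 1.1-fold lower number from compound 2 to compound 3 (0.03 log units; within the scatter)). For compound 3 the estimated value is 8000 nM with an expected range from 3000 nM to 20000 nM (an estimate, not a measurement).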

Compound 3, half-maximal inhibitory concentration: 10300 nM
Compound 3: the middle estimate sits 1.3-fold (0.11 log units) below what was measured, within the range that was stated.
By their numbers in this assay, from the lowest: compounds 2, 3 and 1 (each within the scatter of the next).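

Swapping hexyloxy for octyl on this aromatic carbon, para to a large group, takes the oxygen out of the chain, yet in this assay the change gives a 1.2-fold higher number from compound 2 to compound 3 (0.08 log units; within the scatter) and so no readable effect. Propyl in place of hydrogen on a saturated chain carbon, which extends the pentyl chain to octyl, gives a 1.0-fold lower number from compound 1 to compound 3 (0.01 log units; within the scatter) and is equally unreadable, so pentyl, hexyloxy and octyl cannot be told apart at this position. No measurement is available to explain this flat picture.

From the compounds shown here alone, all three compounds carry a long plain chain here, so it remains open whether a short group such as methyl, or a chain ending in an amine or a carboxylic acid, would give a different number. Going by these compounds, the shared core is also the same throughout, so the effect of changes there remains unknown.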